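The compounds below may be only part of what the source reports. "The series", "measured", "known", "first", "only" and "open" are said of these compounds alone.

Measured compounds on this series:

- compound 1, `COc1cc(CCc2ccc(F)cc2)cc(OC)c1O`: 1190 nM
- compound 2, `COc1cc(CCc2ccccn2)cc(OC)c1O`: 3060 nM
- compound 3, `COc1ccccc1CCc1cc(OC)c(O)c(OC)c1`: 14500 nM

All three were run in a functional assay on HCT-116 cells (Homo sapiens) for antiproliferative activity, read by MTT assay, with a stated time of 72 h; on this read-out higher numbers stand for weaker inhibition and lower numbers for stronger inhibition. Of the three numbers, compound 1 gives the lowest, and its gaps to compound 2 and to compound 3 both lie beyond the usual scatter, so on these numbers compound 1 is the most potent of the measured set. Among the compounds with values here, the three differ from one another in more than one place, so no single step between them is isolated.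

The next compound to run is compound 4, `COc1cc(CCc2ccc([N+](=O)[O-])cc2)cc(OC)c1O`. Relative to compound 1 the change is nitro in place of fluoro on an aromatic carbon, at the same place on the ring, para to a large group. Within the data shown here, no measured pair shows this change, so the step in this assay can only be expected, not derived. Among the measured compounds shown here, the expectation is a step of small size, in either direction or none beyond the scatter, given that the only measured anchor is compound 1 at 1190 nM. Compound 4 is therefore estimated at 1500 nM, with a range from 500 nM to 5000 nM, which would mean an expected step of a 1.3-fold higher number from compound 1 to compound 4 (0.10 log units; within the scatter).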

Compound 4, half-maximal inhibitory concentration: 3160 nM
Estimate against measurement, compound 4: 2.1-fold (0.32 log units) below; measured number inside the range.
By their numbers in this assay, from the lowest: compound 1; then compounds 2 and 4 (each within the scatter of the next); then compound 3.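

In this assay, the place on the aromatic ring para to a large group responds to the choice of substituent: nitro in place of fluoro gives a 2.7-fold higher number from compound 1 to compound 4 (0.42 log units; beyond the scatter), a modest step beyond the scatter. Within the data shown here, this is the first comparison that isolates a single change, and it shows that the aromatic ring carrying fluoro in compound 1 can take nitro with only a modest loss of potency. No available measurement bears on the cause of this step.

With only fluoro and nitro compared at this place, a single step gives no trend across substituents. On these data alone, how an amine, a carboxylic acid or plain hydrogen at the same place would compare with compound 1 remains open.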